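The source may hold more compounds than are shown below. What is called first, only, known or untested is meant among the compounds shown, and "the series" means these compounds.

Three compounds of this series have so far been run in a functional assay on EL4 cells (Mus musculus) for inhibition, tested at 100 uM; a lower number here means less inhibition, a higher number more inhibition at the concentration tested (going by the name of the read-out). Compound 1 `[N-]=[N+]=Nc1nccc2ncn([C@H]3C[C@H](O)[C@@H](CO)O3)c12` returns only the assay limit, < 5%. Compound 2 `CSc1nccc2c1ncn2C1O[C@H](CO)[C@@H](O)[C@H]1O` likewise returns only the limit, < 5%. Compound 3 `Clc1[nH]ccc2ncnc1-2` also stands at the limit, < 5%. All three values therefore sit on the same floor: the limit of < 5% in this assay, at which 3 of the 3 values shown sit. Among the measured compounds shown here, no two measured compounds differ in a single place, so no step size has been measured.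

Compound 4 `Sc1[nH]ccc2ncnc1-2` is the next compound to be measured. Relative to compound 3 it carries sulfanyl in place of chloro on an aromatic carbon. With every measured value at the limit there is no basis for expecting a step beyond the scatter, and compound 4 is expected to stay on the same floor, a step that the limit leaves unreadable from compound 3 to compound 4. The estimate for compound 4 is 3%, in the range 0% to 12%.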

Compound 4, a percentage reported as inhibition, at one concentration (the size of the read-out at that concentration, not a potency): < 5%
Compound 4: a limit, no number; the forecaster's own chance of this, stated with the estimate: 80%; the middle value lies beyond the limit too.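

Compound 3 and compound 4 both stand at a limit in this assay, so sulfanyl in place of chloro gives no readable step. The compounds shown leave open whether any change to the shared core lifts inhibition off this floor: the limit of < 5% in this assay, at which 4 of the 4 values shown sit.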